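The compounds below may be only part of what the source reports. "The series", "measured", "known", "first", "only" and "open" are said of these compounds alone.

Three compounds have been measured in a functional assay (aorta) with Oryctolagus cuniculus as the target; a higher number here means weaker binding, a lower number tighter binding:
compound 1, `COc1cc(C(C)=O)ccc1OCCCCCCN1CCC(C(c2ccc(F)cc2)c2ccc(F)cc2)CC1`, gives 6.31 nM;
compound 2, `COc1cc(C(C)=O)ccc1OCCCN1CCC(C(N)(c2ccc(F)cc2)c2ccc(F)cc2)CC1`, gives 31.6 nM;
compound 3, `CCc1ccc(OCCCN2CCC(C(c3ccc(F)cc3)c3ccc(F)cc3)CC2)c(OC)c1`, gives 2.51 nM.

Among these, compound 3 stands with the lowest number of the three. Compound 1 is its nearest neighbour, with a number higher by a margin beyond the scatter, and compound 2 lies furthest from it, also beyond the scatter. Compound 4, `O=S(=O)(CCCN1CCC(C(c2ccc(F)cc2)c2ccc(F)cc2)CC1)c1ccccc1`, has not yet been measured in this assay. The change from compound 3 to compound 4 is phenylsulfonyl in place of 4-ethyl-2-methoxyphenoxy on a saturated chain carbon, three bonds along the chain from an amine nitrogen in a ring. For the measured compounds named here, no measured pair probes this part of the molecule, so the three measured values give no direct guide to the size of the step. The expected step is a 6.0-fold higher number from compound 3 to compound 4 (0.78 log units; beyond the scatter), toward a higher number and beyond the scatter. For compound 4 the estimate in this assay is 15 nM, with a range from 3 nM to 80 nM.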

Compound 4, dissociation constant: 20 nM
Compound 4: the middle estimate sits 1.3-fold (0.12 log units) below what was measured; the range from low to high includes it.
By their numbers in this assay, from the lowest: compound 3; then compound 1; then compounds 4 and 2 (each within the scatter of the next).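

For the compounds shown here, the step of an 8.0-fold higher number from compound 3 to compound 4 (0.90 log units; beyond the scatter) in this assay gives the first reading at this position, showing that a change of group on this saturated chain carbon can move the number beyond the scatter. The entering phenylsulfonyl keeps the six-membered aromatic ring of carbon only and the same count of hydrogen-bond acceptors as the leaving 4-ethyl-2-methoxyphenoxy, so keeping those two counted features did not keep the number in place. No measured evidence bears on why the number rises with this change.

The compounds shown leave open whether the step follows from the sulfonyl link itself or from the loss of the ethyl and methoxy groups. A plain phenoxy group on the same chain carbon would help to separate these two parts of the change.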